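The source may hold more compounds than are shown below. What is called first, only, known or untested is meant among the compounds shown, and "the series" means these compounds.

Of the compounds shown here, three built on one shared core have been tested in an ADME assay on HepG2 2.2.15 cells (Homo sapiens) for cytotoxicity, read by MTT assay, with stated times of 48 h and 9 days; on this read-out higher numbers stand for lower toxicity in this test and lower numbers for higher toxicity in this test. Compound 1 `COc1ccc2c(=O)c(/C=C/C(=O)Nc3ccc(C)cc3)coc2c1` gives 979000 nM, compound 2 `COc1ccc2c(=O)c(/C=C/C(=O)NCc3cccc(F)c3)coc2c1` gives 475000 nM, and compound 3 `COc1ccc2c(=O)c(/C=C/C(=O)Nc3ccccc3)coc2c1` gives 523000 nM. Compound 3 therefore sits close to both of its companions: a 1.1-fold higher number from compound 2 to compound 3 (0.04 log units; within the scatter), and a 1.9-fold lower number from compound 1 to compound 3 (0.27 log units; within the scatter). Compound 4 `COc1ccc(CNC(=O)/C=C/c2coc3cc(OC)ccc3c2=O)cc1` differs from compound 3 by one exchange, (4-methoxybenzyl in place of phenyl on an amide-type nitrogen). Going by the values given here, the nearest precedent is the exchange of the same kind on that nitrogen, from 4-methylphenyl to 3-fluorobenzyl, which gave a 2.1-fold lower number from compound 1 to compound 2 (0.31 log units; beyond the scatter), whereas the exchange back from a benzyl-type to a phenyl-type group gave a 1.1-fold higher number from compound 2 to compound 3 (0.04 log units; within the scatter). At most a small downward move is expected, probably within the scatter, so compound 4 is estimated at 420000 nM, between 200000 nM and 900000 nM, which means a 1.2-fold lower number from compound 3 to compound 4 (0.10 log units; within the scatter).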

Compound 4, half-maximal cytotoxic concentration: 43000 nM
Estimate against measurement, compound 4: 9.8-fold (0.99 log units) above; measured number below the stated range.
By their numbers in this assay, from the lowest: compound 4; then compounds 2, 3 and 1 (each within the scatter of the next, the first and the last beyond it).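

On this amide-type nitrogen, the choice of group can matter far more than compounds 1 to 3 showed in this assay: 4-methoxybenzyl in place of phenyl gives the largest drop yet for a single exchange from compound 3 (a 12-fold lower number from compound 3 to compound 4 (1.09 log units; beyond the scatter)). A benzyl-type link alone does not produce this, since replacing the 3-fluorophenyl part of compound 2 with 4-methoxyphenyl also gives a large step (an 11-fold lower number from compound 2 to compound 4 (1.04 log units; beyond the scatter)). The exchange from compound 1 gives the widest gap (a 23-fold lower number from compound 1 to compound 4 (1.36 log units; beyond the scatter)).

Nothing shown explains this drop. Going by these compounds, whether it belongs to the methoxy group itself remains open, and an unsubstituted benzyl or a 4-hydroxybenzyl group would help separate the possibilities.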